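The compounds below may be only part of what the source reports. "The series", "measured", "known", "first", "only" and "open" are said of these compounds alone.

Compound 1 `O=C(Nc1ccc(C(F)(F)F)cc1)c1csc(-c2c(Cl)cccc2Cl)n1`: > 4000 nM
Compound 2 `O=C(Nc1ccc(C(F)(F)F)cc1)c1csc(Nc2c(Cl)cccc2Cl)n1`: 51 nM

In an assay on CHO cells, read by calcium flux (on this read-out higher numbers stand for weaker inhibition and lower numbers for stronger inhibition), compound 1 gives > 4000 nM, which is a limit of the assay and not a number. Compound 2 gives 51 nM, the only number shown. Going by the values given here, the single measured step, an at least 78-fold lower number from compound 1 to compound 2 (1.89 log units; beyond the scatter), concerns a change at a different place on the shared core. Compound 3 `O=C(Nc1ccc(C(F)(F)F)cc1)c1csc(Nc2c(Cl)cccc2C(F)(F)F)n1` carries trifluoromethyl in place of chloro on an aromatic carbon. Among the compounds with values here, no measured step bears on this change, so nothing beyond the scatter is expected from it. Compound 3 is therefore expected to give 60 nM, within 20 nM to 200 nM. That estimate means an expected step of a 1.2-fold higher number from compound 2 to compound 3 (0.07 log units; within the scatter).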

Compound 3, half-maximal inhibitory concentration: > 4000 nM
Compound 3 gave a limit, no number; the forecaster's own chance of this, stated with the estimate: 10%; middle value at least 66-fold (1.82 log units) away from the limit.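

In this assay, exchanging one group on an aromatic carbon of compound 2 is enough to lose the activity: an at least 78-fold higher number from compound 2 to compound 3 (1.89 log units; beyond the scatter). The earlier pair had shown only that the amino link matters, whereas this step shows that, with that link kept, the chloro group cannot simply be replaced by trifluoromethyl. For compound 3 the value is a limit of the assay and not a number, so the full size of the step stays unknown: the limit of > 4000 nM in this assay, at which 2 of the 3 values shown sit.

The compounds shown leave open whether fluoro, methyl or methoxy in place of chloro would keep the value of compound 2.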